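Cyclobutylmethyl Replaces 1,1-Dioxothian-4-yl in Compound 2

This account rests on a few compounds, and the source may have more. Where it says the series, first, only, none or still open, it means among the compounds named here.

In a functional assay on Shh Light II cells (Mus musculus) for inhibition, read by a luciferase reporter (a lower number here means a stronger inhibitor, a higher number a weaker inhibitor), compound 1 `CC(C)c1ccccc1NC(=O)N1CCC(c2nc(-c3ccc4ccccc4n3)no2)CC1` gives 480 nM and compound 2 `O=C(NC1CCS(=O)(=O)CC1)N1CCC(c2nc(-c3ccc4ccccc4n3)no2)CC1` gives 360 nM, so the two stand level. Compound 3 `O=C(NCC1CCC1)N1CCC(c2nc(-c3ccc4ccccc4n3)no2)CC1` has cyclobutylmethyl in place of 1,1-dioxothian-4-yl on an amide-type nitrogen. Among the measured compounds shown here, the only measured step at this place, a 1.3-fold lower number from compound 1 to compound 2 (0.12 log units; within the scatter), put 1,1-dioxothian-4-yl in place of 2-isopropylphenyl. On that single step, no change beyond the scatter is expected in this assay, and the direction is open. The expected step is a 1.1-fold higher number from compound 2 to compound 3 (0.05 log units; within the scatter). Compound 3 is estimated at 400 nM, with an expected range from 150 nM to 1100 nM.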

Compound 3, half-maximal inhibitory concentration: 410 nM
For compound 3 the middle estimate is 1.0-fold (0.01 log units) below the measured one; the measured number falls inside the stated range.
By their numbers in this assay, from the lowest: compounds 2, 3 and 1 (each within the scatter of the next).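

In this assay, a small all-carbon group now joins the aromatic 2-isopropylphenyl and the sulfur-containing 1,1-dioxothian-4-yl on this amide-type nitrogen, with a 1.1-fold higher number from compound 2 to compound 3 (0.06 log units; within the scatter) and a 1.2-fold lower number from compound 1 to compound 3 (0.07 log units; within the scatter). Cyclobutylmethyl has fewer heavy atoms than 1,1-dioxothian-4-yl and no hydrogen-bond acceptors, yet compounds 1, 2 and 3 stand level, so across these three compounds neither difference shifts the reading beyond the scatter. No available measurement explains this level reading. As far as these compounds go, whether an amine, a carboxylic acid or a longer chain at this place would also stay level remains open.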